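This account rests on a few compounds, and the source may have more. Where it says the series, first, only, none or still open, it means among the compounds named here.

Of the compounds shown here, three sharing one core have been measured in a physicochemical assay for lipophilicity, read by HPLC, measured as chromatographic lipophilicity, at pH 7.4; a higher number here means a more lipophilic compound, a lower number a more polar compound: compound 1 `O=C(c1cnco1)N1CCC(C(=O)N2N=CC[C@H]2c2ccccc2)CC1` gives 2.7, compound 2 `Cc1nnc(N2CCC(C(=O)N3N=CC[C@H]3c3ccccc3)CC2)o1` gives 3.2, and compound 3 `CC(=O)N1CCC(C(=O)N2N=CC[C@H]2c2ccccc2)CC1` gives 2.5. Compound 3 sits with compound 1 at the low end of these numbers, showing a number 0.20 log units lower from compound 1 to compound 3 (within the scatter). Compound 4 `O=C(C1CCN(c2cccnn2)CC1)N1N=CC[C@H]1c1ccccc1` carries pyridazin-3-yl in place of acetyl on an amine nitrogen in a ring. For the measured compounds named here, no measured compound carries pyridazin-3-yl, so the closest guide is the swap on that same nitrogen, acetyl in place of 5-methyl-1,3,4-oxadiazol-2-yl, which shows a number 0.70 log units lower from compound 2 to compound 3 (beyond the scatter). Read in reverse, that swap points upward, so the expected change in this assay is of similar size, a number 0.60 log units higher from compound 3 to compound 4 (beyond the scatter). Compound 4 is estimated at 3.1, within a range of 2.7 to 3.5.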

Compound 4, distribution coefficient: 3.4
Estimate against measurement, compound 4: 0.30 log units below; the range from low to high includes it.
By their numbers in this assay, from the lowest: compounds 3 and 1 (each within the scatter of the next); then compounds 2 and 4 (each within the scatter of the next).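

In this assay, pyridazin-3-yl on this amine nitrogen gives a number 0.90 log units higher from compound 3 to compound 4 (beyond the scatter) and a number 0.70 log units higher from compound 1 to compound 4 (beyond the scatter) when it replaces a group joined through a carbonyl. Against 5-methyl-1,3,4-oxadiazol-2-yl, the swap gives a number 0.20 log units higher from compound 2 to compound 4 (within the scatter) and so separates the two compounds with a ring joined straight to this nitrogen from the two joined through a carbonyl, with no exception among these four compounds. Nothing available explains these steps. Still open, as far as these compounds go, is where a plain phenyl ring, or a chain ending in an amine or a carboxylic acid, would fall on this nitrogen.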